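Chlorine Position on the Phenoxy Ring and Desaturase Inhibition

The compounds below may be only part of what the source reports. "The series", "measured", "known", "first", "only" and "open" are said of these compounds alone.

Compound 1 `CCC(COc1ccccc1)OC(=O)NCc1ccccc1`: in an assay for inhibition of zeta-carotene desaturase, chloroplastic/chromoplastic (Capsicum annuum), using a Dixon plot, with a stated time of 8 h (on this read-out higher numbers stand for weaker inhibition and lower numbers for stronger inhibition), compound 1 reaches only the limit of the assay, > 100000 nM.
Compound 2 `CCC(COc1ccccc1Cl)OC(=O)NCc1ccccc1`: in this assay compound 2 likewise reaches only the assay limit, > 100000 nM.
Compound 3 `CCC(COc1cccc(Cl)c1)OC(=O)NCc1ccccc1`: in this assay compound 3 again reaches only the assay limit, > 100000 nM.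

Compound 3 thus stands at the limit of > 100000 nM in this assay, at which 3 of the 3 values shown sit. Compound 4 `CCC(COc1ccc(Cl)cc1)OC(=O)NCc1ccccc1` differs from compound 3 in one place: 4-chlorophenyl in place of 3-chlorophenyl on an oxygen on a saturated carbon. The measured steps that bear on moving the chlorine around the phenoxy ring are a step that the two limits leave unreadable from compound 1 to compound 2, a step that the two limits leave unreadable from compound 1 to compound 3 and a step that the two limits leave unreadable from compound 2 to compound 3; none gives a readable size. No direction or size can therefore be inferred for this assay, and the expected outcome is that compound 4 also stays at the limit, an expected step that the limit leaves unreadable from compound 3 to compound 4. Compound 4 is estimated at 150000 nM, within 50000 nM to 500000 nM.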

Compound 4, half-maximal inhibitory concentration: > 100000 nM
Compound 4 ended at the assay's limit; the forecaster's own chance of this, stated with the estimate: 85%; the middle value lies beyond the limit too.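

Going by these compounds alone, compound 1, compound 2, compound 3 and compound 4 all stop at the same limit, so no step among them can be read: the limit of > 100000 nM in this assay, at which 4 of the 4 values shown sit. Going by these compounds, whether the chlorine's position affects inhibition at all remains open.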